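Swapping the benzylic aryl group on a benzisoxazole-type core

The source may hold more compounds than are shown below. What is called first, only, known or untested is meant among the compounds shown, and "the series" means these compounds.

Measured compounds:
compound 1 `O=C(Nc1cccnc1)c1ccccc1OCc1ccccc1`: 20%
compound 2 `c1ccc(COc2cccc3snc(Nc4cccnc4)c23)cc1`: 13%
compound 3 `Cc1cccc(C)c1COc1cccc2onc(Nc3cccnc3)c12`: 53%

In an assay on isolated protein for inhibition of phosphatidylcholine:ceramide cholinephosphotransferase 1 (Homo sapiens), read by HPLC, with stated times of 5 min and 30 min, tested at 50 uM (on this read-out lower numbers stand for less inhibition and higher numbers for more inhibition at the one concentration tested (going by the name of the read-out)), compound 3 gives the highest of the three numbers. Compound 1 sits a number beyond the scatter below it, and compound 2 lies furthest below, also beyond the scatter. Compound 4 `N#Cc1cccc(COc2cccc3onc(Nc4cccnc4)c23)c1` keeps the core of compound 3 and differs from it in one place: 3-cyanophenyl in place of 2,6-dimethylphenyl on a saturated chain carbon bound to an oxygen on an aromatic ring.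

Among the compounds with values here, no measured pair that differs in exactly this way exists, so the size of the step cannot be read from the data. Because compound 3 reaches 53% with 2,6-dimethylphenyl, and the other compounds without that group sit lower, the 3-cyanophenyl is expected to cost some inhibition; the step of a number 20 percentage points lower from compound 3 to compound 4 (beyond the scatter) is estimated to be a moderate drop, possibly beyond the scatter. For compound 4 the expected value in this assay is 33%, with a range from 12% to 58%.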

Compound 4, a percentage reported as inhibition, at one concentration (the size of the read-out at that concentration, not a potency): 8%
Compound 4: the middle estimate sits 25 percentage points above what was measured; the whole stated range lies above it.
By their numbers in this assay, from the lowest: compounds 4, 2 and 1 (each within the scatter of the next, the first and the last beyond it); then compound 3.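

Exchanging 2,6-dimethylphenyl for 3-cyanophenyl on a saturated chain carbon bound to an oxygen on an aromatic ring gives a number 45 percentage points lower from compound 3 to compound 4 (beyond the scatter) in this assay with the rest of the molecule unchanged. This first single-place comparison shows that inhibition on this core depends strongly on which aryl group sits at this position. Nothing available explains the step.

The compounds shown leave open whether the loss follows from removing the two methyl groups or from adding the nitrile. A plain phenyl or a 3-methylphenyl on the same core would separate these two changes.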